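A few compounds are considered here, and "the series" means these few. Any claim that something is new, unique, unknown or untested is made for them only; others in the source may bear on it.

In a functional assay on MCF7 cells (Homo sapiens) for cytotoxicity, read by MTT assay, with a stated time of 24 h (on this read-out higher numbers stand for weaker inhibition and lower numbers for stronger inhibition), compound 1 `CCNc1cc(-c2ccc(NC(=O)Nc3cccc(Cl)c3)cc2C)ccn1` gives 4180 nM and compound 2 `CCNc1cc(-c2ccc(NC(=O)Nc3c(C)cccc3C)cc2C)ccn1` gives 7920 nM, so these two values lie within the usual scatter of each other. Compound 3 `CCNc1cc(-c2ccc(NC(=O)Nc3ccccc3Cl)cc2C)ccn1` has not yet been measured, and its change from compound 2 is 2-chlorophenyl in place of 2,6-dimethylphenyl on an amide-type nitrogen. Among the compounds with values here, only one measured step bears on this change, a 1.9-fold higher number from compound 1 to compound 2 (0.28 log units; within the scatter), which also swaps the group on that amide-type nitrogen. No step beyond the scatter is therefore expected in this assay. The expected step is a 1.4-fold lower number from compound 2 to compound 3 (0.16 log units; within the scatter). For compound 3 the estimated value is 5500 nM, with an expected range of 2700 nM to 11000 nM.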

Compound 3, half-maximal inhibitory concentration: 8350 nM
For compound 3 the middle estimate is 1.5-fold (0.18 log units) below the measured one, within the range that was stated.
By their numbers in this assay, from the lowest: compounds 1, 2 and 3 (each within the scatter of the next).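

In this assay, 2-chlorophenyl in place of 2,6-dimethylphenyl on the amide-type nitrogen gives a 1.1-fold higher number from compound 2 to compound 3 (0.02 log units; within the scatter), and 2-chlorophenyl in place of 3-chlorophenyl gives a 2.0-fold higher number from compound 1 to compound 3 (0.30 log units; within the scatter). Neither the swap of two methyl groups for one chlorine nor the change in chlorine position yields a difference that can be read, so the three groups cannot be told apart here. Nothing available explains this result. Still open, going by these compounds, is whether a carboxylic acid, an amine or a longer alkyl chain on this nitrogen would give a step beyond the scatter.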